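Fluorinating the cyclohexyl ring of a bradykinin antagonist

This account rests on a few compounds, and the source may have more. Where it says the series, first, only, none or still open, it means among the compounds named here.

Measured compounds:
- compound 1, `CC(C)N(O)C(=O)NCc1ncc(-c2cc(Cl)cc(F)c2-c2nnn(C)n2)cc1F`: 1 nM
- compound 2, `Cn1nnc(-c2c(F)cc(Cl)cc2-c2cnc(CNC(=O)N(O)C3CCCCC3)c(F)c2)n1`: 3.9 nM

Both compounds were tested in a functional assay on IMR-90 cells for antagonist activity at B1 bradykinin receptor (Homo sapiens), read by calcium flux; on this read-out higher numbers stand for weaker inhibition and lower numbers for stronger inhibition. Compound 2 gives the higher of the two numbers: it sits a 3.9-fold higher number from compound 1 to compound 2 (0.59 log units; beyond the scatter). Going by the values given here, that step exchanges the isopropyl group on the amide-type nitrogen for a cyclohexyl ring, and it is the only measured step in this set.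

Compound 3, `Cn1nnc(-c2c(F)cc(Cl)cc2-c2cnc(CNC(=O)N(O)C3CCC(F)(F)CC3)c(F)c2)n1`, carries the same core as compound 2 with one alteration: 4,4-difluorocyclohexyl in place of cyclohexyl on an amide-type nitrogen. This change keeps the ring and adds two fluorine atoms to it; the measured step from an isopropyl to a cyclohexyl group concerns a different kind of change and does not directly speak to it. Among the compounds with values here, with no measured step of the same kind, the most defensible expectation is a step that is small, possibly within the scatter, in either direction.

Compound 3 is therefore estimated to show a 1.0-fold higher number from compound 2 to compound 3 (0.01 log units; within the scatter) in this assay. The estimate for compound 3 is 4 nM, expected to fall between 1.5 nM and 12 nM.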

Compound 3, half-maximal inhibitory concentration: 0.19 nM
The estimate for compound 3 lay 21-fold (1.32 log units) above the measured number; measured number below the stated range.
By their numbers in this assay, from the lowest: compound 3; then compound 1; then compound 2.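

In this assay, the change from cyclohexyl to 4,4-difluorocyclohexyl on the amide-type nitrogen gives a 21-fold lower number from compound 2 to compound 3 (1.31 log units; beyond the scatter) and is a large step, so this position responds strongly even when the ring stays and only two fluorine atoms are added. The earlier step, a 3.9-fold higher number from compound 1 to compound 2 (0.59 log units; beyond the scatter) on going from isopropyl to cyclohexyl, had favoured the smaller isopropyl group, but that order does not hold for the fluorinated ring: a 5.3-fold lower number from compound 1 to compound 3 (0.72 log units; beyond the scatter) shows that a six-membered carbon ring can outperform isopropyl here, and compound 2 is the only one of the three that goes against this. No measurement shown here explains why the fluorine atoms have so large an effect.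

Going by these compounds, it remains open whether the gain needs both fluorine atoms, as a monofluorocyclohexyl group would show, or whether it is specific to fluorine, which a methoxycyclohexyl or tetrahydropyranyl ring could test. On these data alone, it is equally open whether fluorine helps on a smaller group, as a trifluoroisopropyl group in place of the isopropyl of compound 1 would show.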